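Nitro on the benzyl ester: a stability step

The compounds below may be only part of what the source reports. "The series", "measured", "known", "first", "only" and "open" are said of these compounds alone.

Of the compounds shown here, two have so far been measured in a physicochemical assay for metabolic stability, at 50 degrees C, tested at 5 uM; on this read-out higher numbers stand for a longer-lived compound and lower numbers for a shorter-lived compound. Compound 1 `Nc1ncnc2c1ncn2[C@@H]1O[C@@H]2CO[P@](=O)(OCc3ccccc3[N+](=O)[O-])O[C@H]2[C@H]1O` gives 300 h. Compound 2 `Nc1ncnc2c1ncn2[C@@H]1O[C@@H]2CO[P@@](=O)(OCc3ccccc3)O[C@H]2[C@H]1O` gives 0.5 h, the lowest of the two numbers: compound 1 stands far above it, by a gap well beyond the scatter of this assay.

The step under study leads from compound 2 to compound 3 `Nc1ncnc2c1ncn2[C@@H]1O[C@@H]2CO[P@@](=O)(OCc3ccccc3[N+](=O)[O-])O[C@H]2[C@H]1O`. The change is small in the count of atoms: nitro in place of hydrogen on an aromatic carbon.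

Among the measured compounds shown here, no measured pair differing only in this one place exists in the set, so the size of the step is open. What the two numbers show is that compound 1, which carries a nitro group on its benzyl ester, lasts very much longer in this assay than compound 2, which does not. On that basis the step of a 200-fold higher number from compound 2 to compound 3 (2.30 log units; beyond the scatter) is expected to be large and upward, reaching compound 3.

Compound 3 is therefore estimated to give 100 h in this assay, with a likely range from 10 h to 400 h.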

Compound 3, half-life: 83 h
Compound 3: middle estimate off by 1.2-fold (0.08 log units), on the high side; the range from low to high includes it.
By their numbers in this assay, from the lowest: compound 2; then compound 3; then compound 1.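

Among the compounds shown here, with compound 3, the nitro group can for the first time be read on its own, with the configuration at phosphorus held as drawn: in this assay, nitro in place of hydrogen on an aromatic carbon, ortho to a large group, gives a 170-fold higher number from compound 2 to compound 3 (2.22 log units; beyond the scatter). Compound 3 also shows that the nitro group does not settle the number alone, since the two 2-nitrobenzyl compounds stand apart, with a 3.6-fold lower number from compound 1 to compound 3 (0.56 log units; beyond the scatter), a step beyond the scatter though much smaller than the one that comes with the nitro group. This second step is assigned to the stereocentre at phosphorus, drawn S in compound 1 and R in compound 3, because the structures leave nothing else to point to: the fact that compounds 1 and 3 differ only in the configuration as drawn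

From the compounds shown here alone, the benzyl ester without the nitro group appears only in the configuration of compound 2, so whether the phosphorus stereocentre counts for as much on that ester stays open. Also open, going by these compounds, is whether a methoxy group or a chlorine atom on the same aromatic carbon would lengthen the half-life as the nitro group does.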